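A few compounds are considered here, and "the series" means these few. Any claim that something is new, unique, unknown or untested is made for them only; others in the source may bear on it.

Measured so far in an in vitro functional assay on HEK293-A cells for positive allosteric modulation of metabotropic glutamate receptor 5 (Homo sapiens), read by FLIPR and calcium flux; a higher number here means that more compound is needed for the effect, a lower number that less compound is needed:
compound 1 `O=C1CC(c2nc(-c3cccc(Cl)c3)no2)CN1c1ccc(Cl)cc1` gives 140 nM
compound 2 `COc1cccc(-c2noc(C3CC(=O)N(c4ccc(Cl)cc4)C3)n2)c1` gives 4800 nM

For the measured compounds named here, compound 1 stands lowest of these two numbers; the only measured step, a 34-fold higher number from compound 1 to compound 2 (1.54 log units; beyond the scatter), lies on the aromatic ring attached to the oxadiazole. Compound 3 `O=C1CC(c2nc(-c3cccc(Cl)c3)no2)CN1c1ccc(Cl)c(Cl)c1` differs from compound 1 by chloro in place of hydrogen on an aromatic carbon. Going by the values given here, that change sits on the other aromatic ring, so the measured step does not bear directly on it, and no step on that ring is known. Compound 3 is therefore expected to stay close to compound 1, within or near the scatter. The expected step is a 1.2-fold lower number from compound 1 to compound 3 (0.07 log units; within the scatter). For compound 3 the estimate is 120 nM, between 40 nM and 400 nM.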

Compound 3, half-maximal effective concentration: 460 nM
The estimate for compound 3 lay 3.8-fold (0.58 log units) below the measured number; the measured number lies above the stated range.
By their numbers in this assay, from the lowest: compound 1; then compound 3; then compound 2.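

In this assay, for the compounds shown here, the change from 4-chlorophenyl to 3,4-dichlorophenyl gives a 3.3-fold higher number from compound 1 to compound 3 (0.52 log units; beyond the scatter) and so shows that this ring, on which no step was known before, also responds to substitution. Here, a chloro group added on the aromatic carbon ortho to the existing chloro group raises the number rather than lowering it. No evidence on hand accounts for this step.

Still open, on these data alone, is whether the rise is specific to chloro at this position. A fluoro, methyl or methoxy group there could behave differently, and the compounds shown do not settle this.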